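A few compounds are considered here, and "the series" means these few. Any claim that something is new, unique, unknown or untested is made for them only; others in the source may bear on it.

Compound 3, with the structure `COc1nc(N)c2nc(O)n(Cc3ccccc3)c2n1`, gives the lowest of the three numbers in a functional assay (spleen, spleen) for activation, with Mus musculus as the target; on this read-out higher numbers stand for an effect only at larger amounts of compound and lower numbers for an effect already at smaller amounts: compound 3 gives 0.1 uM. Compound 1, `CCCCNc1nc(N)c2nc(O)n(Cc3ccccc3)c2n1`, gives 1 uM in this assay, and compound 2, `CCCc1nc(N)c2nc(O)n(Cc3ccccc3)c2n1`, gives 1 uM. The steps towards compound 3 were a 10-fold lower number from compound 1 to compound 3 (1.00 log units; beyond the scatter) and a 10-fold lower number from compound 2 to compound 3 (1.00 log units; beyond the scatter), while the step of no change at the digits printed from compound 1 to compound 2 (within the scatter) shows that the butylamino and propyl compounds stand together.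

Compound 4, `CCCCCSc1nc(N)c2nc(O)n(Cc3ccccc3)c2n1`, takes the next step: pentylsulfanyl in place of methoxy on an aromatic carbon. Both measured steps leading to compound 3 bear on this change, since each replaced a longer chain on the same aromatic carbon with methoxy and each lowered the number by a modest but clear amount. Compound 4 instead carries a chain of five carbons on sulfur, more like compound 1 and compound 2 than like compound 3, so a step back upward in this assay is expected, about a 10-fold higher number from compound 3 to compound 4 (1.00 log units; beyond the scatter). Compound 4 is therefore estimated at 1 uM, with a range from 0.3 uM to 3 uM.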

Compound 4, minimum effective concentration: 10 uM
Compound 4: middle estimate off by 10-fold (1.00 log units), on the low side, outside the stated range (above it).
By their numbers in this assay, from the lowest: compound 3; then compounds 1 and 2 (each within the scatter of the next); then compound 4.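

Going by these compounds alone, at this aromatic carbon, between two ring nitrogen atoms, the earlier compounds showed only two levels in this assay, and pentylsulfanyl opens a third, with a 100-fold higher number from compound 3 to compound 4 (2.00 log units; beyond the scatter) rather than a return to the level of the propyl and butylamino compounds. The separation from those two shows directly in a 10-fold higher number from compound 2 to compound 4 (1.00 log units; beyond the scatter) and in a 10-fold higher number from compound 1 to compound 4 (1.00 log units; beyond the scatter) at the same position, so a longer chain here does not settle at a single level. No measurement at hand accounts for these steps.

The compounds shown leave open whether this rise follows the sulfur or the length of the chain, since pentylsulfanyl differs from methoxy in both. A methylsulfanyl or a pentyloxy group on this carbon would separate the two.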